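Compound 3 to Compound 4: Phenyl Gives Way to (Diethylamino)methyl

The compounds below may be only part of what the source reports. "The series", "measured", "known", "first", "only" and "open" are said of these compounds alone.

In a functional assay on the whole organism with Mus musculus as the target, in the rotarod test (on this read-out higher numbers stand for an effect only at larger amounts of compound and lower numbers for an effect already at smaller amounts), compound 3 (`CN(C(=O)CNC(=O)c1ccccc1)c1ccc(Cl)cc1C(=O)c1ccccc1Cl`) gives > 100 mg/kg as a limit of the assay and not a number. Compound 1 (`CN(C(=O)CNC(=O)CN1CCCCC1)c1ccc(Cl)cc1C(=O)c1ccccc1Cl`) gives > 100 mg/kg and that too is a limit. Both therefore stand at the limit of > 100 mg/kg in this assay, at which 2 of the 3 values shown sit, and neither has a number. Only compound 2 (`CC(C)NCC(=O)NCC(=O)N(C)c1ccc(Cl)cc1C(=O)c1ccccc1Cl`) gives a number, 13 mg/kg on this read-out.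

In compound 4 (`CCN(CC)CC(=O)NCC(=O)N(C)c1ccc(Cl)cc1C(=O)c1ccccc1Cl`) (diethylamino)methyl stands in place of phenyl on a carbonyl carbon ((diethylamino)methyl in place of phenyl on a carbonyl carbon). The nearest measured change is an at least 7.6-fold higher number from compound 2 to compound 3 (0.88 log units; beyond the scatter) when phenyl replaces (isopropylamino)methyl, which suggests that undoing such a swap could bring the number down. Compound 1 goes against any simple rule for amine chains, since it keeps piperidin-1-yl and still shows no number. Its step that the two limits leave unreadable from compound 1 to compound 3 cannot be read, while an at least 7.6-fold lower number from compound 1 to compound 2 (0.88 log units; beyond the scatter) shows that the choice of amine matters. Compound 4 could therefore fall on either side of that divide, and a lower number is expected with modest confidence. The expected change is an at least 2.5-fold lower number from compound 3 to compound 4 (0.39 log units; beyond the scatter) and its size is only an estimate. Compound 4 is expected at 40 mg/kg within an estimated range of 12 mg/kg to 150 mg/kg on this read-out.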

Compound 4, dose for half-maximal effect: 34 mg/kg
Beside the measured number, compound 4's estimate is 1.2-fold (0.07 log units) above it; the measured number falls inside the stated range.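

In this assay, among these compounds, putting (diethylamino)methyl in place of phenyl on a carbonyl carbon gives an at least 2.9-fold lower number from compound 3 to compound 4 (0.46 log units; beyond the scatter), so a second amine chain, after the one in compound 2, comes away from the limit. The amine itself also separates further on the saturated chain carbon bound to a carbonyl carbon: diethylamino in place of piperidin-1-yl gives an at least 2.9-fold lower number from compound 1 to compound 4 (0.46 log units; beyond the scatter), while diethylamino in place of isopropylamino gives a 2.6-fold higher number from compound 2 to compound 4 (0.42 log units; beyond the scatter), so among the amines shown, isopropylamino gives the lowest number and compound 1 goes against any claim that an amine chain alone is enough. Two of these steps start from a value that is a limit of the assay and not a number, so they fix only a minimum size: the limit of > 100 mg/kg in this assay, at which 2 of the 4 values shown sit.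

The compounds shown leave open how other amines on this chain would read, such as dimethylamino, pyrrolidin-1-yl or morpholin-4-yl, and whether the open-chain amines keep their lead over ring amines in general. They also leave open whether a longer chain carrying diethylamino would keep a number on this read-out.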